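One Small Chain Change, Still Unmeasured

The source may hold more compounds than are shown below. What is called first, only, known or untested is meant among the compounds shown, and "the series" means these compounds.

Going by the values given here, in a functional assay on MCF7 cells (Homo sapiens) for cytotoxicity, read by MTT assay, with a stated time of 72 h (on this read-out higher numbers stand for weaker inhibition and lower numbers for stronger inhibition), compound 1 `CC(C)[S+]([O-])CCCCN=C=S` gives 8820 nM, the higher of the two numbers so far, while compound 2 `CC(C)C[S+]([O-])CCCCN=C=S` gives 3660 nM. Compound 3 `CC(C)[S+]([O-])CCCN=C=S` awaits measurement. It differs from compound 1 by a group of 3 heavy atoms (1 carbon, 1 nitrogen, 1 sulfur; no ring) in place of a group of 4 heavy atoms (2 carbon, 1 nitrogen, 1 sulfur; no ring), on a saturated chain carbon, three bonds along the chain from a sulfur, on a saturated chain carbon, three bonds along the chain from a sulfur. Among the compounds with values here, the only measured step, a 2.4-fold lower number from compound 1 to compound 2 (0.38 log units; beyond the scatter), is modest and swaps isobutyl in place of isopropyl on a sulfur, a different change, so it is only a loose guide. In this assay, the estimated step, a 1.4-fold higher number from compound 1 to compound 3 (0.13 log units; within the scatter), is therefore expected to stay within the scatter. Compound 3 is expected at 12000 nM, with a range from 5500 nM to 25000 nM.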

Compound 3, half-maximal inhibitory concentration: 7930 nM
Beside the measured number, compound 3's estimate is 1.5-fold (0.18 log units) above it, and the stated range covers the measured number.
By their numbers in this assay, from the lowest: compound 2; then compounds 3 and 1 (each within the scatter of the next).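

At this place, on a saturated chain carbon, three bonds along the chain from a sulfur, the group of 3 heavy atoms in place of the group of 4 heavy atoms gives a 1.1-fold lower number from compound 1 to compound 3 (0.05 log units; within the scatter) in this assay. So this change cannot be told apart from the ordinary variation between repeated measurements, whereas the swap of isopropyl for isobutyl on the sulfur could. Nothing here offers a reason for this result.

From the compounds shown here alone, what a longer chain or an amine at this place would do remains open. Going by these compounds, it is also open whether isobutyl on the sulfur would give the same step alongside the group of 3 heavy atoms.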